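Removal of the trifluoromethyl from the benzamide of compound 1

This account rests on a few compounds, and the source may have more. Where it says the series, first, only, none or still open, it means among the compounds named here.

Measured so far:
- Compound 1, `COc1cc(-c2nn(-c3cccc(NC(=O)c4cccc(C(F)(F)F)c4)c3)cc2-c2ccncc2)ccc1Cl`: in a functional assay on RPMI-8226 cells (Homo sapiens) for inhibition, read by sulforhodamine B assay, with a stated time of 48 h (a higher number here means a weaker inhibitor of growth, a lower number a stronger inhibitor of growth), compound 1 gives 26600 nM.
- Compound 2, `O=C(Nc1cccc(-n2cc(-c3ccncc3)c(-c3ccc(Cl)c(O)c3)n2)c1)Nc1cc(C(F)(F)F)cc(C(F)(F)F)c1`: in this assay compound 2 reaches only the limit of the assay, > 50000 nM.

Going by the values given here, compound 1 holds the only numerical value in this assay; the other value shown is the limit (the limit of > 50000 nM in this assay, at which 1 of the 2 values shown sits), so no measured step between two numbers exists in this set, and the scatter of the assay is the only yardstick available.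

Compound 3, `COc1cc(-c2nn(-c3cccc(NC(=O)c4ccccc4)c3)cc2-c2ccncc2)ccc1Cl`, is the not yet measured analogue. It differs from compound 1 in one place: hydrogen in place of trifluoromethyl on an aromatic carbon. Nothing measured in this set speaks to the size or direction of such a change, so the expectation rests on compound 1 alone. Compound 3 is expected to lie close to compound 1, with the step from compound 1 to compound 3 estimated at a 1.4-fold higher number from compound 1 to compound 3 (0.15 log units; within the scatter), possibly toward weaker inhibition of growth but not clearly beyond the scatter. The estimate for compound 3 in this assay is 38000 nM, within a range from 14000 nM to 100000 nM.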

Compound 3, concentration for total growth inhibition: > 100000 nM
Compound 3: a limit, no number; the forecaster's own chance of this, stated with the estimate: 35%; at least 2.6-fold (0.42 log units) between middle value and limit.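

In this assay, hydrogen in place of trifluoromethyl on an aromatic carbon, the change from 3-(trifluoromethyl)phenyl to phenyl, gives an at least 3.7-fold higher number from compound 1 to compound 3 (0.57 log units; beyond the scatter). This position is therefore not indifferent to the change: of this pair, only the compound carrying trifluoromethyl gives a number in this assay, although that number is itself modest. The step can be read only as a lower bound, and its true size stays unknown, because compound 3 sits at a limit of the assay and not at a number: the limit of > 100000 nM in this assay, at which 1 of the 3 values shown sits.

From the compounds shown here alone, it remains open whether the drop belongs to trifluoromethyl specifically or whether another group at the same place, such as a methyl, a chlorine, a nitrile or an amine, would hold or improve the growth inhibition seen with compound 1. Compound 2 differs from both compound 1 and compound 3 in more than one place, so steps to it cannot be read, and its limit says nothing about this position.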